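Swapping a Nitro Group for Two Chlorines

The source may report more compounds than this note shows. Statements on the series, on what has been measured and on what is new or still open speak of the compounds shown alone.

Compound 2 `CCC1(Cc2ccccc2)OS(=O)(=O)C=C1OCc1ccc([N+](=O)[O-])cc1` was tested in an ADME assay on HEL cells (Homo sapiens) for cytotoxicity, with a stated time of 3 days; on this read-out higher numbers stand for lower toxicity in this test and lower numbers for higher toxicity in this test. For compound 2 the result is only a limit, < 200000 nM. Compound 1 `CCC1(Cc2ccccc2)OS(=O)(=O)C=C1OCc1ccccc1Cl` gives 38000 nM in this assay. The step that the limit leaves unreadable from compound 1 to compound 2 cannot be sized because of the limit of < 200000 nM in this assay, at which 1 of the 2 values shown sits. Compound 3 `CCC1(Cc2ccccc2)OS(=O)(=O)C=C1OCc1ccc(Cl)c(Cl)c1` differs from compound 2 by 3,4-dichlorophenyl in place of 4-nitrophenyl on a saturated chain carbon bound to an oxygen on an unsaturated carbon. Among the measured compounds shown here, no measured step covers this change, so compound 1, which also carries a chlorine-bearing ring, is the nearest guide. Compound 3 is therefore expected near the value of compound 1. The expected step is a step that the limit leaves unreadable from compound 2 to compound 3. The estimate for compound 3 is 40000 nM, ranging from 10000 nM to 150000 nM.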

Compound 3, half-maximal cytotoxic concentration: 36700 nM
Beside the measured number, compound 3's estimate is 1.1-fold (0.04 log units) above it, and the stated range covers the measured number.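

At this place on the shared core, 3,4-dichlorophenyl and 2-chlorophenyl read alike in this assay, with a 1.0-fold lower number from compound 1 to compound 3 (0.02 log units; within the scatter). The two chlorine-bearing rings therefore cannot be told apart in this test. The steps involving compound 2 cannot be read, because its result is only a limit: the limit of < 200000 nM in this assay, at which 1 of the 3 values shown sits.

Going by these compounds, whether the 4-nitrophenyl ring of compound 2 truly differs from the chlorine-bearing rings stays open. So does the result in this assay for a ring carrying an amine or a carboxylic acid at this place.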